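The source may report more compounds than this note shows. Statements on the series, on what has been measured and on what is new or still open speak of the compounds shown alone.

Four compounds sharing one core are considered here. In a functional assay on MCF7 cells (Homo sapiens) for antiproliferative activity, read by MTT assay, with a stated time of 48 h (a higher number here means a weaker inhibitor, a lower number a stronger inhibitor), compound 1 `COC(=O)/C(=C/c1ccccc1)CN1C(=O)[C@@H](OC)[C@H]1c1ccc(Cl)cc1` gives 15300 nM and compound 2 `CCOC(=O)/C(=C/c1ccccc1)CN1C(=O)[C@@H](OC)[C@H]1c1ccc(Cl)cc1` gives 12700 nM. These two numbers lie within the scatter of each other, so compound 2 stands level with compound 1. For compound 3 `COC(=O)/C(=C/c1ccccc1)CN1C(=O)[C@@H](OC)[C@H]1c1ccc(Cl)cc1Cl`, the outcome reads no result reported, which leaves only these two numbers as a reference.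

The next compound to be tested is compound 4 `CCOC(=O)/C(=C/c1ccccc1)CN1C(=O)[C@@H](OC)[C@H]1c1ccccc1Br`. Relative to compound 2, it carries 2-bromophenyl in place of 4-chlorophenyl on a saturated ring carbon. Going by the values given here, the only measured step is a 1.2-fold lower number from compound 1 to compound 2 (0.08 log units; within the scatter). That step is methyl in place of hydrogen on a saturated chain carbon bound to an oxygen next to a carbonyl group, so it lies elsewhere in the structure and only shows that this one change left the number within the scatter. Among the compounds with values here, no measured step covers the saturated ring carbon that changes here, so the data give neither a size nor a direction for this replacement.

With no evidence for a shift, no step beyond the scatter is expected in this assay, though the uncertainty is wide. The expected step is a 1.1-fold lower number from compound 2 to compound 4 (0.02 log units; within the scatter). For compound 4 the estimated value is 12000 nM, with an expected range from 4500 nM to 30000 nM.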

Compound 4, half-maximal inhibitory concentration: 5790 nM
Estimate against measurement, compound 4: 2.1-fold (0.32 log units) above; the range from low to high includes it.
By their numbers in this assay, from the lowest: compound 4; then compounds 2 and 1 (each within the scatter of the next).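

In this assay, going by these compounds alone, replacing 4-chlorophenyl with 2-bromophenyl gives a 2.2-fold lower number from compound 2 to compound 4 (0.34 log units; beyond the scatter) and is a modest step, but it is the first step to lie beyond the scatter. The only earlier step, on the ester chain, stayed within the scatter, so this saturated ring carbon next to the ring nitrogen is the first place shown where a change moves the number, and it moves toward a stronger inhibitor. Nothing in the available data accounts for this shift.

The halogen and its place on the phenyl group change together in this single step, so the compounds shown cannot separate the two, and 2-chlorophenyl or 4-bromophenyl would each be needed to change only one of them. They also leave open how the number would read with unsubstituted phenyl at this carbon, or with a methoxy group or an amine on the phenyl group in place of the halogen.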